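Series notes: phenyl to 5-methyl-1,2-oxazol-3-yl on compound 3

The source may report more compounds than this note shows. Statements on the series, on what has been measured and on what is new or still open speak of the compounds shown alone.

Three compounds of the series share the dithiocarbamate tail and have been run in a functional assay on Bel-7402 cells (Homo sapiens) for cytotoxicity, read by resazurin assay, with a stated time of 72 h; on this read-out lower numbers stand for stronger inhibition and higher numbers for weaker inhibition. Compound 1 `CCCCOC(=O)CCSC(=S)NCc1cccnc1` gives 6350 nM. Compound 2 `S=C(NCc1cccnc1)SCCc1nc2ccccc2o1` gives 2880 nM. Compound 3 `S=C(NCc1cccnc1)SCCc1nnc(-c2ccccc2)o1` gives 1230 nM, the lowest of the three numbers; compound 2 stands nearest to it and compound 1 furthest, both gaps beyond the scatter, so compound 3 is the most potent of the measured set in this assay.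

Compound 4 `Cc1cc(-c2nnc(CCSC(=S)NCc3cccnc3)o2)no1` has not been measured. It differs from compound 3 in one place: 5-methyl-1,2-oxazol-3-yl in place of phenyl on an aromatic carbon. The two groups are of the same heavy-atom count, and the entering group brings hydrogen-bond acceptors where the leaving one has none. Among the measured compounds shown here, no measured pair reports such an exchange, so there is no step to read a direction from; what is known is only that compound 3 already sits at the low end of the numbers.

The expectation is therefore a small step in this assay, most likely a slight rise in the number, of a size that may not exceed the scatter, as a 1.6-fold higher number from compound 3 to compound 4 (0.21 log units; within the scatter). For compound 4 the estimate in this assay is 2000 nM, within a range from 700 nM to 6000 nM.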

Compound 4, half-maximal inhibitory concentration: 1680 nM
The estimate for compound 4 lay 1.2-fold (0.08 log units) above the measured number, within the range that was stated.
By their numbers in this assay, from the lowest: compounds 3, 4 and 2 (each within the scatter of the next, the first and the last beyond it); then compound 1.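

In this assay, among the compounds shown here, the exchange of phenyl for 5-methyl-1,2-oxazol-3-yl on the aromatic carbon gives a 1.4-fold higher number from compound 3 to compound 4 (0.14 log units; within the scatter) and is the first change that can be read at a single place, since the earlier compounds differ from one another in more than one place. At this position of the shared core, a six-membered aromatic ring of carbon only and a five-membered aromatic ring with hetero atoms and hydrogen-bond acceptors of the same heavy-atom count cannot be told apart on this read-out, so the entry of those acceptors leaves no mark that stands clear of the scatter. Nothing in hand offers an account of this result.

Still open, on these data alone, is whether the position accepts a saturated ring such as cyclohexyl, or a phenyl carrying an amine or a carboxylic acid, as readily as it accepts these two aromatic groups. Also open, as far as these compounds go, is what the methyl contributes, which the unsubstituted 1,2-oxazol-3-yl group would address.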